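Bromo on the benzyl of compound 1

This account rests on a few compounds, and the source may have more. Where it says the series, first, only, none or still open, it means among the compounds named here.

Among the measured compounds shown here, compound 1 `Cc1cc(Nc2ccc(C(=O)/C=C/c3cccc(Br)n3)cc2)n2nc(SCc3ccccc3)nc2n1` gives 90.2% in a functional assay on MGC-803 cells (Homo sapiens) for inhibition, read by sulforhodamine B assay, with a stated time of 72 h, tested at 10 uM (on this read-out lower numbers stand for less inhibition and higher numbers for more inhibition at the one concentration tested (going by the name of the read-out)), the highest of the three numbers so far. Compound 2 `CCc1cc(Nc2ccc(C(=O)/C=C/c3cccc(Br)n3)cc2)n2nc(SCc3ccccc3)nc2n1` gives 63%, and compound 3 `O=C(/C=C/c1cccc(Br)n1)c1ccc(Nc2cc(-c3ccccc3)nc3nc(SCc4ccccc4)nn23)cc1` gives 38.3%; the steps of a number 27.2 percentage points lower from compound 1 to compound 2 (beyond the scatter) and a number 51.9 percentage points lower from compound 1 to compound 3 (beyond the scatter) both alter the group on the shared core, not the benzylsulfanyl part. Compound 4 `Cc1cc(Nc2ccc(C(=O)/C=C/c3cccc(Br)n3)cc2)n2nc(SCc3ccc(Br)cc3)nc2n1` keeps the methyl of compound 1 and differs from it elsewhere: bromo in place of hydrogen on an aromatic carbon. For the measured compounds named here, no measured step touches the benzyl, so the measured steps give no direct guide; the change is a single bromo on an otherwise unchanged compound. A step within the scatter is therefore expected, a number 5.2 percentage points lower from compound 1 to compound 4 (within the scatter). Compound 4 is estimated at 85%, with a range from 65% to 96%.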

Compound 4, a percentage reported as inhibition, at one concentration (the size of the read-out at that concentration, not a potency): 96.3%
Estimate against measurement, compound 4: 11.3 percentage points below; the whole stated range lies below it.
By their numbers in this assay, from the lowest: compound 3; then compound 2; then compounds 1 and 4 (each within the scatter of the next).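

Benzylsulfanyl to (4-bromobenzyl)sulfanyl gives a number 6.1 percentage points higher from compound 1 to compound 4 (within the scatter) in this assay, the first reading on the benzyl. Unlike the changes on the shared core in compound 2 and compound 3, which each gave a step beyond the scatter, this bromo leaves the number within the scatter of compound 1, though a single pair describes this position. Nothing available bears on the reason for this result. Still open, from the compounds shown here alone, is whether an amine or a carboxylic acid on that same aromatic carbon would also stay within the scatter of compound 1.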